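Methylamino for methoxy on the benzofuranyl core

This account rests on a few compounds, and the source may have more. Where it says the series, first, only, none or still open, it means among the compounds named here.

Compound 1 `CNc1ncnc2c1c(I)cn2[C@@H]1O[C@H](CO)[C@@H](O)[C@H]1O` and compound 2 `COc1ncnc2c1c(I)cn2[C@@H]1O[C@H](CO)[C@@H](O)[C@H]1O` share one core; compound 3 `COc1ncnc2c1c(-c1cc3ccccc3o1)cn2[C@@H]1O[C@H](CO)[C@@H](O)[C@H]1O` carries another, and compound 4 `CNc1ncnc2c1c(-c1cc3ccccc3o1)cn2[C@@H]1O[C@H](CO)[C@@H](O)[C@H]1O` is still to be measured. The cores of compound 2 and compound 3 differ by 1-benzofuran-2-yl in place of iodo on an aromatic carbon. In a functional assay on HCT-116 cells (Homo sapiens), read by MTT assay, with a stated time of 72 h (a lower number here means a stronger inhibitor, a higher number a weaker inhibitor), compound 1 gives only a limit, > 100000 nM (the limit of > 100000 nM in this assay, at which 1 of the 3 values shown sits). Compound 2 likewise gives only a limit in this assay, > 20000 nM (the limit of > 20000 nM in this assay, at which 1 of the 3 values shown sits). Compound 3 gives 14500 nM in this assay, a step of an at least 1.3-fold lower number from compound 2 to compound 3 (0.13 log units; that floor lies within the scatter). The change from compound 2 to compound 1 is methylamino in place of methoxy on an aromatic carbon, a step that the two limits leave unreadable from compound 2 to compound 1. Compound 4 arises from compound 3 by the same change, (methylamino in place of methoxy on an aromatic carbon). Because the step that the two limits leave unreadable from compound 2 to compound 1 rests on two limits, it gives no direction. Compound 4 is therefore expected to move by a 1.0-fold higher number from compound 3 to compound 4 (0.01 log units; within the scatter). The estimate for compound 4 is 15000 nM, expected between 4000 nM and 60000 nM.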

Compound 4, half-maximal inhibitory concentration: > 20000 nM
Compound 4: a limit, no number; the forecaster's own chance of this, stated with the estimate: 30%; middle value at least 1.3-fold (0.12 log units) away from the limit.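

In this assay compound 4 gives only a limit, not a number: the limit of > 20000 nM in this assay, at which 2 of the 4 values shown sit.

On the core of compound 3, methylamino in place of methoxy gives an at least 1.3-fold higher number from compound 3 to compound 4 (0.13 log units; that floor lies within the scatter), which shows no gain from the change on this core but does not establish a loss. The steps with a limit at both ends cannot be read, and no size for the change can be compared between the two cores, leaving its transfer from one core to the other unshown.

On these data alone, the true position of compound 4 beyond its limit remains open. Also open, as far as these compounds go, is whether another group at this place on the core of compound 3, such as dimethylamino or ethoxy, gives a number clearly apart from that of compound 3.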